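Adding a Methyl Group to a Weakly Cytotoxic Compound

This account rests on a few compounds, and the source may have more. Where it says the series, first, only, none or still open, it means among the compounds named here.

Compound 1, `Cc1cnc(Nc2ccc(C#N)cc2)nc1NC1CCCCC1`: 1300 nM
Compound 2, `N#Cc1ccc(Nc2nccc(OC3CCCCC3)n2)cc1`: 322000 nM

In an ADME assay on MT4 cells (Homo sapiens) for cytotoxicity, read by MTT assay (on this read-out lower numbers stand for higher toxicity in this test and higher numbers for lower toxicity in this test), compound 2 gives 322000 nM, the highest of the two numbers and far above compound 1, which gives 1300 nM. Compound 3, `Cc1cnc(Nc2ccc(C#N)cc2)nc1OC1CCCCC1`, differs from compound 2 by methyl in place of hydrogen on an aromatic carbon. Among the measured compounds shown here, no measured pair shows this change on its own, so its effect is unknown. A small step is expected, a 2.1-fold lower number from compound 2 to compound 3 (0.33 log units; beyond the scatter), most likely towards a somewhat lower number. Compound 3 is therefore estimated at 150000 nM, within a range from 30000 nM to 500000 nM.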

Compound 3, half-maximal cytotoxic concentration: 31200 nM
Compound 3: the middle estimate sits 4.8-fold (0.68 log units) above what was measured; measured number inside the range.
By their numbers in this assay, from the lowest: compound 1; then compound 3; then compound 2.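

In this assay, methyl in place of hydrogen on this aromatic carbon, ortho to the cyclohexyloxy group, gives a 10-fold lower number from compound 2 to compound 3 (1.01 log units; beyond the scatter), so one added carbon here goes with a large change. With that methyl present in both compounds, cyclohexyloxy in place of cyclohexylamino gives a 24-fold higher number from compound 1 to compound 3 (1.38 log units; beyond the scatter), a large step in the opposite direction. Nothing available explains either step.

As far as these compounds go, it remains open whether an ethyl group or a chlorine atom at this position would lower the number further. From the compounds shown here alone, whether the methyl step would have the same size with cyclohexylamino in place of cyclohexyloxy also remains open.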